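A few compounds are considered here, and "the series" means these few. Any claim that something is new, unique, unknown or untested is made for them only; others in the source may bear on it.

Working notes on the series. Compound 1 `NC1=NC2(CCSCC2)N(OCCCOc2ccc(Cl)c(Cl)c2)C(N)=N1` and compound 2 `NC1=NC2(CCSCC2)N(OCCCOc2ccccc2Cl)C(N)=N1` share the same core and differ only in the aryl group on the oxygen on the saturated carbon. In an assay on isolated protein for inhibition of Dihydrofolate reductase (Homo sapiens), read by spectrophotometry, using NADPH, with stated times of 5 s and 6 min, tested at 50 uM (a lower number here means a weaker effect, a higher number a stronger effect of the compound at the concentration tested), compound 1 gives 89.8%; in this assay compound 2 gives 89.6%. Compound 2 therefore sits beside compound 1 at the same level, the step of a number 0.2 percentage points lower from compound 1 to compound 2 (within the scatter) being within the scatter of repeated measurements.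

Compound 3 `COc1ccc(OCCCON2C(N)=NC(N)=NC23CCSCC3)cc1` is not yet measured. Its change from compound 2 is 4-methoxyphenyl in place of 2-chlorophenyl on an oxygen on a saturated carbon. Within the data shown here, the only measured step that bears on it is the aryl swap at the same place, a number 0.2 percentage points lower from compound 1 to compound 2 (within the scatter), which stayed within the scatter; no measured step covers a methoxy group. A step of a number 3.6 percentage points lower from compound 2 to compound 3 (within the scatter) is therefore expected, that is none beyond the scatter. Compound 3 is estimated at 86% in this assay, within 70% to 96%.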

Compound 3, a percentage reported as inhibition, at one concentration (the size of the read-out at that concentration, not a potency): 86.6%
Estimate against measurement, compound 3: 0.6 percentage points below; the measured number falls inside the stated range.
By their numbers in this assay, from the lowest: compounds 3, 2 and 1 (each within the scatter of the next).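

The change from 2-chlorophenyl to 4-methoxyphenyl on an oxygen on a saturated carbon gives a number 3 percentage points lower from compound 2 to compound 3 (within the scatter), and the change from 3,4-dichlorophenyl gives a number 3.2 percentage points lower from compound 1 to compound 3 (within the scatter). In this assay, the position therefore now holds an aryl group without chlorine, with a methoxy group and one hydrogen-bond acceptor, at the same level as the two chlorinated groups, and the three compounds cannot be ordered. Nothing at hand gives a reason for this flat reading.

A single-concentration read-out at this level leaves open whether potency differences lie behind these three numbers. It also leaves open whether an amine or a carboxylic acid on the aryl ring, or a longer chain in place of the saturated chain, would move the number beyond the scatter.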